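A few compounds are considered here, and "the series" means these few. Any claim that something is new, unique, unknown or untested is made for them only; others in the source may bear on it.

Measured compounds
- compound 1 `CCOC(=O)CCCCCOc1cccc(CN(C(=O)c2ccc(-c3cccc(NC(C)=O)c3)cc2)C(C)C)c1`: in an ADME assay on BJ cells (Homo sapiens) for cytotoxicity, read by CellTiter-Glo and resazurin assay, with a stated time of 72 h (a lower number here means that less compound is needed, a higher number that more compound is needed for the effect), compound 1 gives > 26000 nM
- compound 2 `CCOC(=O)CCCCCOc1cccc(CN(C(=O)c2ccc(-c3ccc4[nH]ccc4c3)cc2)C(C)C)c1`: in this assay compound 2 gives > 26000 nM

The value of compound 1 is a limit of this assay, not a number. The value of compound 2 is likewise a limit. Both shown values sit at the limit of > 26000 nM in this assay, at which 2 of the 2 values shown sit, so compound 2 stands only at a limit, with no number to place it against. Within the data shown here, the single measured step, a step that the two limits leave unreadable from compound 1 to compound 2, gives no readable size.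

Compound 3 `CCOC(=O)CCCCCOc1cccc(CN(C(=O)c2ccc(-c3ccc4cc[nH]c4c3)cc2)C(C)C)c1` is the next variation: 1H-indol-6-yl in place of 1H-indol-5-yl on an aromatic carbon. Among the measured compounds shown here, no measured step bears on this change, and the one step that exists is unreadable, so no direction beyond the scatter is expected; the estimated step is a step that the limit leaves unreadable from compound 2 to compound 3. On that basis compound 3 is expected to give 40000 nM in this assay, with a range from 13000 nM to 150000 nM, most likely again reported only as a limit.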

Compound 3, half-maximal effective concentration: > 26000 nM
Compound 3 gave a limit, no number; the forecaster's own chance of this, stated with the estimate: 85%; the middle value does not contradict the limit.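

No step can be read among compound 1, compound 2 and compound 3, since all three values are limits of this assay and not numbers: the limit of > 26000 nM in this assay, at which 3 of the 3 values shown sit.

Still open, from the compounds shown here alone, is whether 1H-indol-6-yl, 1H-indol-5-yl or 3-acetamidophenyl makes any difference in this assay.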